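The source may hold more compounds than are shown below. What is called first, only, known or untested is meant among the compounds shown, and "the series" means these compounds.

Compound 1, whose structure is `CCC1(Cc2ccccc2)OS(=O)(=O)C=C1OCc1ccc(OC)cc1`, was tested in an ADME assay on HEL cells (Homo sapiens) for cytotoxicity, with a stated time of 3 days; on this read-out higher numbers stand for lower toxicity in this test and lower numbers for higher toxicity in this test. In this assay compound 1 reaches only the limit of the measurement, > 200000 nM, so no exact number is known for it. Two other compounds share its core. Compound 2, `CCC1(Cc2ccccc2)OS(=O)(=O)C=C1OS(=O)(=O)c1ccc(C)cc1`, gives 109000 nM in this assay. Compound 3, `CCC1(Cc2ccccc2)OS(=O)(=O)C=C1OC(c1ccccc1)c1ccccc1`, also reaches only the limit in this assay, > 200000 nM. Going by the values given here, compound 1 therefore stands at the limit of > 200000 nM in this assay, at which 2 of the 3 values shown sit, and no step between two measured compounds that differ in a single place is available for comparison. Compound 4, `CCC1(Cc2ccccc2)OS(=O)(=O)C=C1OCc1cccc(Cl)c1`, has not yet been measured. It differs from compound 1 by 3-chlorophenyl in place of 4-methoxyphenyl on a saturated chain carbon bound to an oxygen on an unsaturated carbon. Because the values at hand cluster at the limit of > 200000 nM in this assay, at which 2 of the 3 values shown sit, and compound 2 gives a number in the same region, this change is expected to produce no step beyond the usual scatter, and compound 4 is expected to end up at or near the same limit. The expected result for compound 4 in this assay is 200000 nM, with a likely range from 100000 nM to 400000 nM, which means a step of a number no higher from compound 1 to compound 4 (the limit leaves the size open) that is estimated to lie within the scatter.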

Compound 4, half-maximal cytotoxic concentration: 50000 nM
For compound 4 the middle estimate is 4.0-fold (0.60 log units) above the measured one; the whole stated range lies above it.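

Replacing 4-methoxyphenyl with 3-chlorophenyl gives an at least 4.0-fold lower number from compound 1 to compound 4 (0.60 log units; beyond the scatter) in this assay. Going by these compounds alone, this is the first single-place comparison, and it shows that the group on this saturated chain carbon bound to an oxygen on an unsaturated carbon can shift the read-out toward higher toxicity in this test. The true size of the step stays open, because the value for compound 1 is a limit of the assay and not a number: the limit of > 200000 nM in this assay, at which 2 of the 4 values shown sit.

The compounds shown leave open whether the step comes from gaining the chlorine, losing the methoxy group or the place of each on the ring. From the compounds shown here alone, how a plain phenyl, an amine or a carboxylic acid in the same place would read in this assay is also open.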